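Trading a Hydroxymethyl Amide for a Carboxymethyl Amide

A few compounds are considered here, and "the series" means these few. Any claim that something is new, unique, unknown or untested is made for them only; others in the source may bear on it.

Compound 1 `CCn1c(C(=O)N[C@@H](C)C(=O)OC)ccc1C(CC)(CC)c1ccc(OCS(=O)(=O)c2ccccc2)c(C)c1`, compound 2 `CCn1c(C(=O)N[C@@H](C)CO)ccc1C(CC)(CC)c1ccc(OCS(=O)(=O)c2ccccc2)c(C)c1` and compound 3 `CCn1c(C(=O)NC(C)(C)CO)ccc1C(CC)(CC)c1ccc(OCS(=O)(=O)c2ccccc2)c(C)c1` share one core and differ only in the group on the amide-type nitrogen. In a functional assay on MCF7 cells (Homo sapiens) for antiproliferative activity, read by MTT assay, with a stated time of 24 h (a lower number here means a stronger inhibitor, a higher number a weaker inhibitor), compound 1 gives 43700 nM, compound 2 gives 10800 nM and compound 3 gives 20700 nM, which places compound 3 second highest of the three numbers. The step of a 4.0-fold lower number from compound 1 to compound 2 (0.61 log units; beyond the scatter) and the step of a 2.1-fold lower number from compound 1 to compound 3 (0.32 log units; beyond the scatter) are modest gains, while a 1.9-fold higher number from compound 2 to compound 3 (0.28 log units; within the scatter) stays within the scatter. Compound 4 `CCn1c(C(=O)NCC(=O)O)ccc1C(CC)(CC)c1ccc(OCS(=O)(=O)c2ccccc2)c(C)c1` carries the change (carboxymethyl in place of 1-(hydroxymethyl)-1-methylethyl on an amide-type nitrogen). Among the compounds with values here, no measured step brings in a carboxymethyl group, so the narrow spread among compounds 1 to 3 is the only guide. The expected step is therefore a 1.4-fold higher number from compound 3 to compound 4 (0.16 log units; within the scatter). Compound 4 is estimated at 30000 nM, with a range from 10000 nM to 90000 nM.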

Compound 4, half-maximal inhibitory concentration: 33100 nM
Beside the measured number, compound 4's estimate is 1.1-fold (0.04 log units) below it, and the stated range covers the measured number.
By their numbers in this assay, from the lowest: compounds 2, 3, 4 and 1 (each within the scatter of the next, the first and the last beyond it).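

In this assay, carboxymethyl on the amide-type nitrogen leaves compound 4 level with two earlier compounds, with a 1.6-fold higher number from compound 3 to compound 4 (0.20 log units; within the scatter) and a 1.3-fold lower number from compound 1 to compound 4 (0.12 log units; within the scatter), but it loses ground against the 1-(hydroxymethyl)ethyl group, with a 3.1-fold higher number from compound 2 to compound 4 (0.49 log units; beyond the scatter). The position therefore tolerates carboxymethyl about as well as the 1-(hydroxymethyl)-1-methylethyl and 1-(methoxycarbonyl)ethyl groups, while the 1-(hydroxymethyl)ethyl group of compound 2 remains ahead of it. No evidence is available to explain these differences. As far as these compounds go, whether an amine or a longer chain ending in a hydroxyl group would give a lower number at this nitrogen stays open.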